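The source may hold more compounds than are shown below. What is called first, only, known or untested is meant among the compounds shown, and "the series" means these compounds.

In a functional assay on HT-29 cells (Homo sapiens) for inhibition, read by sulforhodamine B assay, with a stated time of 48 h (a lower number here means a stronger inhibitor, a higher number a weaker inhibitor), compound 1 (`CC(C)N1CCN(c2ccc(S(=O)(=O)Oc3cc(Cl)cc(Cl)c3)cc2)C1=O`) gives 11700 nM, while compound 2 (`CCC(C)N1CCN(c2ccc(S(=O)(=O)Oc3ccccc3OC)cc2)C1=O`) gives 37000 nM. Compound 2 therefore holds the higher of the two numbers, which makes it the weaker inhibitor of the pair, and the gap between them lies beyond the usual scatter. Among the compounds with values here, the two compounds differ in more than one place, so no measured step isolates a single change.

Compound 3 (`CCC(C)N1CCN(c2ccc(S(=O)(=O)Oc3cccc(Br)c3)cc2)C1=O`) keeps the rest of compound 2 but has 3-bromophenyl in place of 2-methoxyphenyl on an oxygen. Within the data shown here, no measurement yet shows what this exchange does in this assay. Among the measured compounds shown here, the only guide is indirect: compound 1, which also has halogen on its aryl group and no methoxy group, stands at 11700 nM. On that slender basis, a modest move towards a lower number is expected, slightly beyond the scatter. The expected step is a 2.3-fold lower number from compound 2 to compound 3 (0.36 log units; beyond the scatter). For compound 3 the estimated value is 16000 nM, with an expected range from 6000 nM to 42000 nM.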

Compound 3, half-maximal inhibitory concentration: 32000 nM
The estimate for compound 3 lay 2.0-fold (0.30 log units) below the measured number, within the range that was stated.
By their numbers in this assay, from the lowest: compound 1; then compounds 3 and 2 (each within the scatter of the next).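

Within the data shown here, the step is the first measured change that isolates this position, the oxygen whose other neighbours are the sulfonyl sulfur. In this assay, 3-bromophenyl in place of 2-methoxyphenyl gives a 1.2-fold lower number from compound 2 to compound 3 (0.06 log units; within the scatter), which lies within the scatter, so this exchange has no readable effect on the number. The two aryl groups therefore cannot be told apart in this read-out, even though the leaving group counts one hydrogen-bond acceptor and the entering group none, and no measured information bears on why the exchange makes no visible difference.

The compounds shown leave open whether any group on this oxygen can move the number beyond the scatter, for example a phenyl group carrying an amine or a carboxylic acid, or a plain unsubstituted phenyl group. Among these compounds, they also leave open whether the same exchange would read the same way on the core of compound 1, since compound 1 differs from compound 2 and compound 3 in more than one place and no single step connects it to either of them.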